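Working notes: from compound 2 to compound 3

This account rests on a few compounds, and the source may have more. Where it says the series, first, only, none or still open, it means among the compounds named here.

compound 1 `CC(=O)NCc1ccc2c(c1)nc(Cn1c(=O)n(C(C)C)c3ccccc31)n2CCC(C)C` gives 178000 nM
compound 2 `CC(C)CCn1c(Cn2c(=O)n(C(C)C)c3ccccc32)nc2cc(C(C)(C)N)ccc21` gives 3270 nM

In an ADME assay on HEp-2 cells (Homo sapiens) for cytotoxicity (a lower number here means that less compound is tolerated, a higher number that more compound is tolerated), compound 2 stands lowest of the two measured compounds at 3270 nM. Compound 3 `CC(C)CCn1c(Cn2c(=O)n(C(C)C)c3ccccc32)nc2cc(Br)ccc21` has not yet been measured. It carries bromo in place of 1-amino-1-methylethyl on an aromatic carbon of the shared core: bromo in place of 1-amino-1-methylethyl on an aromatic carbon. Among the measured compounds shown here, only one measured step bears on this change, and it falls at the same place: a 54-fold lower number from compound 1 to compound 2 (1.74 log units; beyond the scatter). That step is large. Compound 3 gives up the 1-amino-1-methylethyl group, so a move back toward the value of compound 1 is expected. Bromo itself is unmeasured in this series, so the full return is not assumed. A rise beyond the scatter in this assay is expected, as an estimated 12-fold higher number from compound 2 to compound 3 (1.09 log units; beyond the scatter). For compound 3 the expected value is 40000 nM, with an estimated range of 10000 nM to 150000 nM.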

Compound 3, half-maximal cytotoxic concentration: 18100 nM
For compound 3 the middle estimate is 2.2-fold (0.34 log units) above the measured one, and the stated range covers the measured number.
By their numbers in this assay, from the lowest: compound 2; then compound 3; then compound 1.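

In this assay bromo at this aromatic carbon brings a 5.5-fold higher number from compound 2 to compound 3 (0.74 log units; beyond the scatter) but still a 9.8-fold lower number from compound 1 to compound 3 (0.99 log units; beyond the scatter) and so takes the middle place among the three groups seen here. A number lower than that of compound 1 therefore does not depend on the 1-amino-1-methylethyl group, although compound 2, which carries that group, remains lowest of the three. Nothing available explains either step.

As far as these compounds go, it remains open whether the low number of compound 2 follows the amine or the branched carbon of 1-amino-1-methylethyl, a question that a tert-butyl or an aminomethyl group on this aromatic carbon could help to separate. Also open, from the compounds shown here alone, is whether a carboxylic acid on this carbon would move the number back toward that of compound 1 or beyond it.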